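A step from dimethylamino to diethylamino

The compounds below may be only part of what the source reports. "The series", "measured", "known", "first", "only" and "open" are said of these compounds alone.

Values from a functional assay on HeLa cells (Homo sapiens) for cytotoxicity, read by CCK-8 assay (on this read-out higher numbers stand for weaker inhibition and lower numbers for stronger inhibition), are these
Compound 1 `COc1ccc(NC(=O)c2ncc(-c3ccccc3)o2)cc1` gives > 30000 nM
Compound 2 `CN(C)c1ccc(NC(=O)c2ncc(-c3ccccc3)o2)cc1` gives > 30000 nM

In this assay compound 2 reads > 30000 nM and this is a limit, not a number. The measured compounds offer only the limit of > 30000 nM in this assay, at which 2 of the 2 values shown sit, and no exact value. Compound 3 `CCN(CC)c1ccc(NC(=O)c2ncc(-c3ccccc3)o2)cc1` differs from compound 2 in one place (diethylamino in place of dimethylamino on an aromatic carbon) and carries diethylamino in place of dimethylamino. Among the measured compounds shown here, one measured step bears on this change, since it swaps the group at that same place, but it is a step that the two limits leave unreadable from compound 1 to compound 2 and gives no size to carry over. No step beyond the scatter is therefore expected in this assay, and no direction can be expected either. The expected step is a number no higher from compound 2 to compound 3 (the limit leaves the size open) and it should be read as a rough guide. For compound 3 the estimate is 30000 nM with an expected range from 12000 nM to 60000 nM and a good chance of another limit.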

Compound 3, half-maximal inhibitory concentration: > 30000 nM
Compound 3: only a limit was reported; the forecaster's own chance of this, stated with the estimate: 75%; the middle value sits exactly at the limit.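

No new step can be read among compound 1, compound 2 and compound 3 in this assay, because each gives only a limit and not a number: the limit of > 30000 nM in this assay, at which 3 of the 3 values shown sit.

The compounds shown leave open whether methoxy, dimethylamino and diethylamino differ at all on this read-out.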